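The source may report more compounds than this note shows. Statements on the series, on what has been measured and on what is new or still open speak of the compounds shown alone.

In a functional assay on MCF7 cells (Homo sapiens) for cytotoxicity, read by sulforhodamine B assay, with a stated time of 48 h (a higher number here means a weaker inhibitor, a lower number a stronger inhibitor), compound 1 `COc1ccc(N2CCN(c3ncnc4scc(-c5ccc(Cl)cc5)c34)CC2)cc1` gives 48.5 nM, and compound 2 `Clc1ccc(-c2csc3ncnc(N4CCN(c5ccc(Cl)cc5)CC4)c23)cc1` gives 42.6 nM. Going by the values given here, the single measured step, a 1.1-fold lower number from compound 1 to compound 2 (0.06 log units; within the scatter), is the only one-place comparison the set offers. Compound 3 `CN(C)c1ccc(/C=N\Nc2ncnc3scc(-c4ccc([N+](=O)[O-])cc4)c23)cc1` gives 10.2 nM in this assay; among the three numbers this is the lowest, and its gaps to compound 2 and to compound 1 both lie beyond the scatter.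

Compound 4 `COc1ccc(/C=N\Nc2ncnc3scc(-c4ccc([N+](=O)[O-])cc4)c23)cc1OC` differs from compound 3 by 3,4-dimethoxyphenyl in place of 4-(dimethylamino)phenyl on a carbon with a double bond to nitrogen. Among the compounds with values here, no measured pair covers a change of this kind: the step from compound 1 to compound 2 swaps one group for another on a different part of the shared core, on a phenyl attached to the piperazine, and it stayed within the scatter. It bears on the present step only loosely, as an indication that a change to the aryl group on this side of the core need not move the number far. The data are therefore expected to show a small step in this assay from compound 3 to compound 4, a 1.6-fold higher number from compound 3 to compound 4 (0.20 log units; within the scatter), probably upward but not beyond the scatter. For compound 4 the estimate is 16 nM, within 5 nM to 50 nM.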

Compound 4, half-maximal inhibitory concentration: 32.6 nM
The estimate for compound 4 lay 2.0-fold (0.31 log units) below the measured number; measured number inside the range.
By their numbers in this assay, from the lowest: compound 3; then compounds 4, 2 and 1 (each within the scatter of the next).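

In this assay, replacing 4-(dimethylamino)phenyl with 3,4-dimethoxyphenyl on a carbon with a double bond to nitrogen moves the number beyond the scatter (a 3.2-fold higher number from compound 3 to compound 4 (0.50 log units; beyond the scatter)), with the lower number belonging to the compound that carries 4-(dimethylamino)phenyl. Going by these compounds alone, the earlier compounds could not show this: their only one-place step (a 1.1-fold lower number from compound 1 to compound 2 (0.06 log units; within the scatter)) lay within the scatter and concerned a phenyl attached to the piperazine, so this is the first sign that the choice of aryl group can matter at a site in this set, though it rests on a single pair and its size is only modest. The data shown offer no measurement that would account for the step.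

Within the data shown here, with only two aryl groups compared on this carbon, the pair cannot separate the departure of the dimethylamino group from the arrival of the two methoxy groups as the source of the step. From the compounds shown here alone, whether an unsubstituted phenyl, a phenyl with a single methoxy group, or a phenyl with a primary amine or a hydroxyl group would sit closer to compound 3 or to compound 4 remains open.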